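Extending the sulfamoylamino linker by one carbon

A few compounds are considered here, and "the series" means these few. Any claim that something is new, unique, unknown or untested is made for them only; others in the source may bear on it.

Compound 2 `NS(=O)(=O)NCC1CCN(c2cc(-c3ccc(C(F)(F)F)cc3)ncn2)CC1` and compound 1 `NS(=O)(=O)NCC1CCN(c2cc(-c3ccc(Cl)cc3)ncn2)CC1` share one core and differ only in the group on the aromatic carbon. In a functional assay on M21 cells (Homo sapiens) for antiproliferative activity, read by sulforhodamine B assay, with a stated time of 48 h (on this read-out higher numbers stand for weaker inhibition of growth and lower numbers for stronger inhibition of growth), compound 1 gives 50300 nM, and in this assay compound 2 gives 43100 nM. The step of a 1.2-fold lower number from compound 1 to compound 2 (0.07 log units; within the scatter) leaves compound 2 with the lower of the two numbers, yet within the scatter of compound 1, so no order between them can be read. Compound 3 `NS(=O)(=O)NCCC1CCN(c2cc(-c3ccc(C(F)(F)F)cc3)ncn2)CC1` keeps the trifluoromethyl of compound 2 and differs from it in one place: (sulfamoylamino)methyl in place of sulfamoylamino on a saturated chain carbon bound to a saturated ring carbon. Going by the values given here, no measured step touches this part of the molecule; the single measured step concerns the aromatic substituent and lay within the scatter. Nothing measured therefore speaks for a shift in this assay beyond the scatter in either direction. Compound 3 is accordingly expected close to compound 2, with an estimated step of a 1.0-fold lower number from compound 2 to compound 3 (0.00 log units; within the scatter). The estimate for compound 3 is 43000 nM, with a range from 15000 nM to 130000 nM.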

Compound 3, concentration for 50% growth inhibition: 34800 nM
Estimate against measurement, compound 3: 1.2-fold (0.09 log units) above, within the range that was stated.
By their numbers in this assay, from the lowest: compounds 3, 2 and 1 (each within the scatter of the next).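

Going by these compounds alone, compound 3 gives the first measured look at the linker itself, since the only earlier step concerned the aromatic substituent. In this assay, (sulfamoylamino)methyl in place of sulfamoylamino on a saturated chain carbon bound to a saturated ring carbon gives a 1.2-fold lower number from compound 2 to compound 3 (0.09 log units; within the scatter), so with trifluoromethyl on the aromatic ring, the added carbon does not shift growth inhibition beyond the scatter. Nothing available explains this result.

As far as these compounds go, it remains open whether a longer chain, such as 3-(sulfamoylamino)propyl, or an amine or a carboxylic acid in place of the sulfamoylamino group would move the number beyond the scatter. From the compounds shown here alone, it also remains open whether the same chain extension would give a similar step with chloro in place of trifluoromethyl.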